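The compounds below may be only part of what the source reports. "The series", "measured", "known", "first", "only" and "open" are said of these compounds alone.

Working notes on the series. Of the compounds shown here, two of the shared core have been measured: compound 1 `COc1cc2c(Oc3ccc(NC(=O)c4cn(-c5ccccc5Cl)nn4)cc3F)ccnc2cc1OCCCN1CCCC1` and compound 2 `COc1cc2c(Oc3ccc(NC(=O)c4cn(-c5ccccc5)nn4)cc3F)ccnc2cc1OCCCN1CCC(C)CC1`. In a functional assay on HT-29 cells (Homo sapiens) for cytotoxicity, read by MTT assay, with a stated time of 72 h (a higher number here means a weaker inhibitor, a lower number a stronger inhibitor), compound 1 gives 150 nM. In this assay, within the data shown here, compound 2 gives 190 nM, the highest of the two numbers so far; its nearest neighbour is compound 1, and the gap between the two lies within the scatter, so on the numbers the two cannot be told apart. Among the measured compounds shown here, compound 1 and compound 2 differ from each other in two places at once, so no single-point step between measured compounds is available.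

Compound 3 `COc1cc2c(Oc3ccc(NC(=O)c4cn(-c5ccccc5Cl)nn4)cc3F)ccnc2cc1OCCCN1CCC(C)CC1` has not yet been measured in this assay. Relative to compound 2 the change is chloro in place of hydrogen on an aromatic carbon. Compound 3 thus carries the 2-chlorophenyl group of compound 1 together with the rest of compound 2, and no shown step isolates this change on its own. The step from compound 2 to compound 3 is expected to be small, a 1.2-fold lower number from compound 2 to compound 3 (0.07 log units; within the scatter), with no direction beyond the scatter. Compound 3 is therefore estimated at 160 nM, within a range of 70 nM to 350 nM.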

Compound 3, half-maximal inhibitory concentration: 130 nM
Estimate against measurement, compound 3: 1.2-fold (0.09 log units) above; measured number inside the range.
By their numbers in this assay, from the lowest: compounds 3, 1 and 2 (each within the scatter of the next).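

In this assay, the change from phenyl to 2-chlorophenyl, chloro in place of hydrogen on an aromatic carbon ortho to a large group, reads as a 1.5-fold lower number from compound 2 to compound 3 (0.16 log units; within the scatter) with the 4-methylpiperidin-1-yl group held fixed. The second single-point change, 4-methylpiperidin-1-yl in place of pyrrolidin-1-yl on a saturated chain carbon, reads as a 1.2-fold lower number from compound 1 to compound 3 (0.06 log units; within the scatter) with the 2-chlorophenyl group held fixed. Taken one at a time, neither change moves the number beyond the scatter, a reading that the earlier pair, differing in two places at once, could not give, and no measured evidence available here bears on this result.

From the compounds shown here alone, each change has been read against one background only, so the chloro step with pyrrolidin-1-yl at the chain end and the amine step with an unsubstituted phenyl remain open. Also open, going by these compounds, is whether a group of another kind would leave the number within the scatter, such as methoxy or nitrile in place of the chloro, or morpholin-4-yl or a dimethylamino group in place of the 4-methylpiperidin-1-yl.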